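Amino Group on the Shared Core and Loss of Potency

The source may hold more compounds than are shown below. What is called first, only, known or untested is meant among the compounds shown, and "the series" means these compounds.

Measured compounds:
Compound 1, `COc1ncnc2c1c(-c1ccsc1)cn2[C@@H]1O[C@H](CO)[C@@H](O)[C@H]1O`, 90 nM
Compound 3, `COc1ncnc2c1c(-c1cccs1)cn2[C@@H]1O[C@H](CO)[C@@H](O)[C@H]1O`, 70 nM
Compound 2, `COc1nc(N)nc2c1c(-c1ccsc1)cn2[C@@H]1O[C@H](CO)[C@@H](O)[C@H]1O`, gives only a limit of the assay, > 20000 nM

All three were tested in a functional assay on K562 cells (Homo sapiens), read by MTT assay, with a stated time of 72 h; on this read-out lower numbers stand for stronger inhibition and higher numbers for weaker inhibition. Compound 1 and compound 3 share one core and differ only in the thiophene ring attached to it: thiophen-2-yl in place of thiophen-3-yl on an aromatic carbon. This swap made a 1.3-fold lower number from compound 1 to compound 3 (0.11 log units; within the scatter), so the two compounds cannot be told apart on potency.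

The second change is the one that matters here. Compound 2 carries an amino group where compound 1 carries a hydrogen: amino in place of hydrogen on an aromatic carbon. This gave an at least 220-fold higher number from compound 1 to compound 2 (2.34 log units; beyond the scatter), and the value of compound 2 is only a limit, because the step runs into (the limit of > 20000 nM in this assay, at which 1 of the 3 values shown sits).

Compound 4, `COc1nc(N)nc2c1c(-c1cccs1)cn2[C@@H]1O[C@H](CO)[C@@H](O)[C@H]1O`, has not yet been measured. It stands to compound 3 exactly as compound 2 stands to compound 1: amino in place of hydrogen on an aromatic carbon. The place of the change is described in the same words for both pairs, so this is the same change made on a core that differs only in the thiophene ring, a difference that itself gave a 1.3-fold lower number from compound 1 to compound 3 (0.11 log units; within the scatter). For compound 4 the expected step is therefore a 360-fold higher number from compound 3 to compound 4 (2.55 log units; beyond the scatter), resting on compound 1 to compound 2 having given an at least 220-fold higher number from compound 1 to compound 2 (2.34 log units; beyond the scatter). Compound 4 is estimated at 25000 nM, most likely reported only as a limit, with a range from 7000 nM to 100000 nM.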

Compound 4, half-maximal inhibitory concentration: > 20000 nM
Compound 4 gave a limit, no number; the forecaster's own chance of this, stated with the estimate: 85%; the middle value does not contradict the limit.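

In this assay, amino in place of hydrogen on the aromatic carbon between two ring nitrogen atoms gave an at least 280-fold higher number from compound 3 to compound 4 (2.45 log units; beyond the scatter), so the large loss of potency seen with the thiophen-3-yl core appears again with the thiophen-2-yl core. Both steps are large and run in the same direction, so on these two closely related cores the effect of the change carries over: the same change on two cores in this assay, an at least 220-fold higher number (2.34 log units; beyond the scatter) from compound 1 to compound 2 and an at least 280-fold higher number (2.45 log units; beyond the scatter) from compound 3 to compound 4; the limit leaves it open whether they differ This does not give the true size of either loss or show what the change would do on a more different core, and the step from compound 2 to compound 4 cannot be read, as both values are limits: the limit of > 20000 nM in this assay, at which 2 of the 4 values shown sit.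

The compounds shown leave open whether a methyl group, a chlorine atom or a methylamino group on the same aromatic carbon would cost as much potency as the amino group. They also leave open whether the amino group would have the same effect if a phenyl group took the place of the thiophene or an ethoxy group took the place of the methoxy group.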